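Furan-3-yl in Place of Thiophen-3-yl: Expecting Another Limit

The source may report more compounds than this note shows. Statements on the series, on what has been measured and on what is new or still open speak of the compounds shown alone.

Of the compounds shown here, three built on one shared core have been measured. Compound 1 `O=C(Nc1cccc(-c2ccccc2C(F)(F)F)c1)C(Cl)Cl` was tested in a functional assay on NCI-H460 cells (Homo sapiens) for cytotoxicity, read by MTT assay, with a stated time of 68 h (a lower number here means a stronger inhibitor, a higher number a weaker inhibitor), where compound 1 gives 7550 nM. Compound 2 `O=C(Nc1cccc(-c2ccc(F)cc2)c1)C(Cl)Cl` reaches only the limit of this assay, where compound 2 gives > 50000 nM, which is a limit and not a number. Compound 3 `O=C(Nc1cccc(-c2ccsc2)c1)C(Cl)Cl` likewise stands at the limit of this assay, where compound 3 gives > 50000 nM, so no number is known for it; it shares this position with another member of the set, as shown by the limit of > 50000 nM in this assay, at which 2 of the 3 values shown sit. Compound 4 `O=C(Nc1cccc(-c2ccoc2)c1)C(Cl)Cl` differs from compound 3 in one place: furan-3-yl in place of thiophen-3-yl on an aromatic carbon. Among the compounds with values here, no measured pair in this set shows what that change does to this assay, and compound 3 itself gives no number to step from. Compound 4 is therefore expected to remain at or near the limit of this assay, with an estimated value of 60000 nM, between 20000 nM and 200000 nM. The estimated step that the limit leaves unreadable from compound 3 to compound 4 is expected to be none beyond the usual scatter.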

Compound 4, half-maximal inhibitory concentration: 37600 nM
Compound 4: middle estimate off by 1.6-fold (0.20 log units), on the high side; low and high end bracket the measured number.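

In this assay compound 4, carrying furan-3-yl, gives 37600 nM, so this position on the shared core can return a measured number with a five-membered aromatic ring bearing one hetero atom. Furan-3-yl in place of thiophen-3-yl gives an at least 1.3-fold lower number from compound 3 to compound 4 (0.12 log units; that floor lies within the scatter). That size is only a floor, because compound 3 holds a limit and not a number: the limit of > 50000 nM in this assay, at which 2 of the 4 values shown sit.

How far compound 3 truly lies from compound 4 stays open, so the compounds shown cannot tell whether swapping sulfur for oxygen in this ring changes the result beyond the usual scatter. Also open, from the compounds shown here alone, is what this position would do with a pyridin-3-yl ring, or with an amine or a carboxylic acid on the five-membered ring.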